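The compounds below may be only part of what the source reports. "The series", "measured", "known", "first", "only" and "open" are said of these compounds alone.

Working notes on the series. In an ADME assay on HEL cells (Homo sapiens) for cytotoxicity (a higher number here means that more compound is tolerated, a lower number that less compound is tolerated), compound 1 `O=C(COc1cccc2ccccc12)N/N=C/c1ccc(O)cc1` gives 20 ug/mL. Compound 2 `C/C(=N\NC(=O)COc1cccc2ccccc12)c1ccccc1` gives 20 ug/mL and compound 3 `O=C(COc1cccc2ccccc12)N/N=C/c1ccc([N+](=O)[O-])cc1` gives 20 ug/mL in this assay, so compound 1 stands level with both, compound 2 being the nearest and compound 3 the furthest, neither separated from it beyond the scatter. For the measured compounds named here, the one single-point step measured, no change at the digits printed from compound 1 to compound 3 (within the scatter), lies within the scatter. Compound 4 `O=C(COc1cccc2ccccc12)N/N=C/c1ccccc1O` differs from compound 1 by 2-hydroxyphenyl in place of 4-hydroxyphenyl on a carbon with a double bond to nitrogen. Going by the values given here, no measured step moves a hydroxy group within the ring, but the one aromatic substituent change measured gave no movement and all three measured compounds sit at one value. The expected step is therefore no change at the digits printed from compound 1 to compound 4 (within the scatter), nothing beyond the scatter. Compound 4 is expected to give 20 ug/mL, within 10 ug/mL to 40 ug/mL.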

Compound 4, minimum cytotoxic concentration: 20 ug/mL
Beside the measured number, compound 4's estimate shows no gap at the digits printed; the range from low to high includes it.
By their numbers in this assay, from the lowest: compounds 1, 2, 3 and 4 (each within the scatter of the next).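

In this assay, swapping 2-hydroxyphenyl for 4-hydroxyphenyl on a carbon with a double bond to nitrogen gives no change at the digits printed from compound 1 to compound 4 (within the scatter). The earlier step replaced the hydroxy group with nitro, whereas this one keeps the group and changes only its place on the aromatic ring, so the reading now covers a change of position as well as a change of substituent. No supporting data bear on this result. On these data alone, it remains open whether an amine or a carboxylic acid in place of the hydroxy group would separate from these values, and how changes to the shared core would read.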